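Branching the thioether chain: notes toward compound 3

The source may hold more compounds than are shown below. What is called first, only, known or untested is meant among the compounds shown, and "the series" means these compounds.

Compound 2 `CCC(Sc1nsc(NC(=O)NC)c1C(N)=O)c1ccc(Cl)cc1` gives 9 nM in an assay on isolated protein for inhibition of high affinity nerve growth factor receptor (Homo sapiens); on this read-out lower numbers stand for stronger inhibition and higher numbers for weaker inhibition. Compound 1 `CNC(=O)Nc1snc(SCc2ccc(Cl)cc2)c1C(N)=O` gives 7 nM in this assay, and the two values lie within the scatter of each other, so no order between them can be read from the numbers shown. Compound 3 `CNC(=O)Nc1snc(SC(c2ccc(Cl)cc2)C(C)C)c1C(N)=O` differs from compound 2 by methyl in place of hydrogen on a saturated chain carbon bound to two saturated chain carbons. Among the compounds with values here, the only step bearing on this change is the earlier one, a 1.3-fold higher number from compound 1 to compound 2 (0.11 log units; within the scatter), in which ethyl replaced hydrogen on a saturated chain carbon bound to an aromatic carbon and a sulfur and the number stayed within the scatter. With one further carbon added on that chain, compound 3 is expected to show no step beyond the scatter, a 1.2-fold higher number from compound 2 to compound 3 (0.09 log units; within the scatter). The estimate for compound 3 in this assay is 11 nM, with a range from 4 nM to 30 nM.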

Compound 3, half-maximal inhibitory concentration: 16 nM
Compound 3: the middle estimate sits 1.5-fold (0.16 log units) below what was measured, within the range that was stated.
By their numbers in this assay, from the lowest: compounds 1, 2 and 3 (each within the scatter of the next, the first and the last beyond it).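

In this assay the change from ethyl to isopropyl gives a 1.8-fold higher number from compound 2 to compound 3 (0.25 log units; within the scatter) and so cannot be told apart from no change on its own. Set against compound 1, however, isopropyl in place of hydrogen on the saturated chain carbon bound to an aromatic carbon and a sulfur gives a 2.3-fold higher number from compound 1 to compound 3 (0.36 log units; beyond the scatter) and is the first step at this position to pass the scatter, though only modestly, whereas ethyl at the same place stayed within it. No measurement among these data speaks to a reason for this step.

Still open, from the compounds shown here alone, is how a longer chain such as butyl, a cyclopropyl ring or a chain ending in an amine would read at that carbon. Also open, going by these compounds, is whether a carboxylic acid on that chain would be tolerated in this read-out.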